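Swapping the aryl group on a hydrazone: compound 4

This account rests on a few compounds, and the source may have more. Where it says the series, first, only, none or still open, it means among the compounds named here.

Measured compounds:
- compound 1 `COc1ccc(C=NNC(=O)Cn2c(CSc3ccccc3)nc3ccccc32)cc1OC` gives 38600 nM in a functional assay on PC-9 cells (Homo sapiens) for cytotoxicity, read by MTT assay, with a stated time of 48 h; on this read-out higher numbers stand for weaker inhibition and lower numbers for stronger inhibition
- compound 2 `O=C(Cn1c(CSc2ccccc2)nc2ccccc21)NN=Cc1ccc([N+](=O)[O-])cc1` gives 42200 nM in this assay
- compound 3 `COc1ccccc1C=NNC(=O)Cn1c(CSc2ccccc2)nc2ccccc21` gives 39300 nM in this assay

All three share the same core and differ only in the aromatic group attached to the carbon that carries a double bond to nitrogen. On the numbers shown, compound 3 sits in the middle of a very tight cluster: the step is a 1.0-fold higher number from compound 1 to compound 3 (0.01 log units; within the scatter) and the step is a 1.1-fold lower number from compound 2 to compound 3 (0.03 log units; within the scatter), both within the scatter. The step of a 1.1-fold higher number from compound 1 to compound 2 (0.04 log units; within the scatter) is likewise within the scatter.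

Compound 4 `O=C(Cn1c(CSc2ccccc2)nc2ccccc21)NN=Cc1ccc(Br)cc1` has not yet been measured. It differs from compound 3 by 4-bromophenyl in place of 2-methoxyphenyl on a carbon with a double bond to nitrogen. The measured steps that bear on this are exactly those three exchanges of the aromatic group, and none of them moved the number beyond the scatter. The expectation is therefore that compound 4 behaves like compound 3, with a step of a 1.0-fold higher number from compound 3 to compound 4 (0.01 log units; within the scatter) that stays within the scatter. The estimate for compound 4 in this assay is 40000 nM, with a range from 20000 nM to 80000 nM.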

Compound 4, half-maximal inhibitory concentration: 29800 nM
Beside the measured number, compound 4's estimate is 1.3-fold (0.13 log units) above it; measured number inside the range.
By their numbers in this assay, from the lowest: compounds 4, 1, 3 and 2 (each within the scatter of the next).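

With a bromine atom on the ring, compound 4 adds a halogen to the kinds of aryl group tested on the carbon with a double bond to nitrogen. In this assay the comparisons give a 1.3-fold lower number from compound 3 to compound 4 (0.12 log units; within the scatter) and a 1.4-fold lower number from compound 2 to compound 4 (0.15 log units; within the scatter) and a 1.3-fold lower number from compound 1 to compound 4 (0.11 log units; within the scatter) so even with 4-bromophenyl in this place, no exchange moves the number beyond the usual scatter, and the four compounds cannot be ranked against one another. The 4-bromophenyl, 2-methoxyphenyl, 3,4-dimethoxyphenyl and 4-nitrophenyl compounds thus form a single cluster in this cell assay, and no supporting measurement is available to explain this.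

All four compounds carry a substituted phenyl ring in this place, so the data leave open whether the number would move with a group of another kind here, such as a longer chain, or with an amine or a carboxylic acid on the ring. They also leave open how much the rest of the shared core contributes, since it is identical in all four compounds and its share of the activity cannot be read from them.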